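The source may hold more compounds than are shown below. What is called first, only, known or untested is meant among the compounds shown, and "the series" means these compounds.

Measured compounds and their values:

compound 1, `CC(C)(C)OC(=O)N1CCN(c2ncc(-c3ccc(OCC#N)cc3)cn2)CC1`, 81%
compound 2, `Cc1cc(COc2cnc(N3CCN(C(=O)OC(C)(C)C)CC3)nc2)ccn1`, 19%
compound 3, `CC(C)OC(=O)N1CCN(c2ncc(OCc3ccncc3C#N)cn2)[C@H](C)C1`, 171%

All three were tested in an in vitro functional assay on HEK293S cells with Glucose-dependent insulinotropic receptor (Homo sapiens) as the target, read by HTRF and cAMP accumulation, with a stated time of 45 min; on this read-out lower numbers stand for smaller maximal responses and higher numbers for larger maximal responses. Among them compound 3 gives the highest number. Its nearest neighbour is compound 1, whose number lies clearly lower, beyond the scatter, and the furthest is compound 2, whose number lies lower still, also beyond the scatter. Compound 3 therefore stands at the top of this small set, with a maximal response that goes well past the reference agonist.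

The step under consideration leads to compound 4, `C[C@@H]1CN(c2nc(C3CC3)no2)CCN1c1ncc(OCc2ccncc2C#N)cn1`. It differs from compound 3 in one place: 3-cyclopropyl-1,2,4-oxadiazol-5-yl in place of isopropoxycarbonyl on an amine nitrogen in a ring. Within the data shown here, none of the three measured compounds share a change at this amine nitrogen, so no measured step tells how this assay answers such a replacement; the pairs among compounds 1, 2 and 3 each differ in several places at once and offer no single-point comparison.

Starting from the high number of compound 3 in this assay, a moderate decrease is expected for compound 4, a step of a number 31 percentage points lower from compound 3 to compound 4 (beyond the scatter), though a result within the scatter would not surprise. Compound 4 is accordingly estimated at 140%, with a range from 90% to 190%.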

Compound 4, intrinsic activity: the largest response reached, in percent of the reference agonist's: 224%
Estimate against measurement, compound 4: 84 percentage points below; the measured number lies above the stated range.
By their numbers in this assay, from the lowest: compound 2; then compound 1; then compound 3; then compound 4.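

Among these compounds, with a number 53 percentage points higher from compound 3 to compound 4 (beyond the scatter) in this assay, the replacement of isopropoxycarbonyl by 3-cyclopropyl-1,2,4-oxadiazol-5-yl gives the first comparison in which only this amine nitrogen changes. It shows that isopropoxycarbonyl is not needed at this position for a maximal response beyond that of the reference agonist, and that a group with a five-membered aromatic ring and a three-membered carbon ring can take its place with a large gain rather than a loss. No measurement shown gives a reason for this gain, and the step describes only this one replacement on the core of compound 3.

As far as these compounds go, what a methyl or a tert-butyl group in place of the cyclopropyl would do on the 1,2,4-oxadiazole remains open, so the shares of the aromatic ring and of the cyclopropyl in this step cannot be told apart. Equally open, from the compounds shown here alone, is whether the same replacement would give a like step without the methyl group on the six-membered ring, and how an acetyl or a benzyl group on this amine nitrogen would compare.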